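One More Carbon on the Saturated Chain

This account rests on a few compounds, and the source may have more. Where it says the series, first, only, none or still open, it means among the compounds named here.

Measured compounds:
Compound 1, `CCCCCCCCNc1ccccc1-c1ccccc1`: -4%
Compound 2, `CCCCCCCCNc1cccc(-c2ccccc2)c1`: -20%

Of the compounds shown here, two have been tested so far. In an in vitro assay on BTI-TN-5B1-4 cells for inhibition of sterol O-acyltransferase 2 (Homo sapiens), tested at 50 uM (on this read-out higher numbers stand for more inhibition at the one concentration tested (going by the name of the read-out) and lower numbers for less inhibition), compound 1 gives -4%, the higher of the two numbers, while compound 2 gives -20%, a gap that lies beyond the usual scatter. Both numbers sit at or under zero, so neither compound shows any real inhibition at the concentration used.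

Compound 3, `CCCCCCCCCNc1ccccc1-c1ccccc1`, is the next one to be measured. Compared with compound 1 the change is small: methyl in place of hydrogen on a saturated chain carbon, eight bonds along the chain from a nitrogen on an aromatic ring. Within the data shown here, no pair of measured compounds differs in this way, so nothing measured yet tells how such a change plays out here. With a single added carbon far from the aromatic ring, the step from compound 1 is expected to be modest, a number 4 percentage points higher from compound 1 to compound 3 (within the scatter), within the scatter. Compound 3 is therefore expected to give about 0%, somewhere between -15% and 15%.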

Compound 3, a percentage reported as inhibition, at one concentration (the size of the read-out at that concentration, not a potency): -1%
The estimate for compound 3 lay 1 percentage points above the measured number; the range from low to high includes it.
By their numbers in this assay, from the lowest: compound 2; then compounds 1 and 3 (each within the scatter of the next).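

In this assay, methyl in place of hydrogen on a saturated chain carbon, eight bonds along the chain from a nitrogen on an aromatic ring, gives a number 3 percentage points higher from compound 1 to compound 3 (within the scatter), so compound 1 and compound 3 cannot be told apart. Among these compounds, this is the first measured change at this position, and it shows that one added carbon here does not bring out inhibition: compound 3 gives -1% at the one concentration tested. Nothing available on these compounds speaks to a cause for this result.

A single step cannot show whether a longer chain, or a chain ending in an amine or a carboxylic acid, would give real inhibition. Going by these compounds, whether the same added carbon would behave alike on the core of compound 2 also remains open.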